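Compound 3: cyclopentylmethyl in place of phenyl on the chain

The compounds below may be only part of what the source reports. "The series", "measured", "known", "first", "only" and "open" are said of these compounds alone.

In a functional assay on NUGC-3 cells (Homo sapiens) for antiproliferative activity, read by sulforhodamine B assay (on this read-out higher numbers stand for weaker inhibition of growth and lower numbers for stronger inhibition of growth), compound 1 (`CCCCOc1cccc(O)c1C(=O)/C=C/c1ccc(O)cc1`) gives > 30000 nM as a limit of the assay and not a number. Compound 2 (`O=C(/C=C/c1ccc(O)cc1)c1c(O)cccc1OCc1ccccc1`) gives > 30000 nM in this assay and this too is only a limit. Among the measured compounds shown here, the series so far shows the limit of > 30000 nM in this assay, at which 2 of the 2 values shown sit, and so compound 2 has no graded position. For the measured compounds named here, the one measured step is a step that the two limits leave unreadable from compound 1 to compound 2 and it offers no size to carry forward.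

Compound 3 (`O=C(/C=C/c1ccc(O)cc1)c1c(O)cccc1OCCC1CCCC1`) carries cyclopentylmethyl in place of phenyl on a saturated chain carbon bound to an oxygen on an aromatic ring, counted as cyclopentylmethyl in place of phenyl on a saturated chain carbon bound to an oxygen on an aromatic ring in full. The same difference reads benzyloxy to 2-cyclopentylethoxy.

With no readable step, the expectation rests on compound 2 at > 30000 nM as a limit alone. No step beyond the scatter is expected, and a further limit is the likeliest report. The expected change is a number no higher from compound 2 to compound 3 (the limit leaves the size open) in this assay as a rough figure only. For compound 3 the estimate is 30000 nM within an expected range of 10000 nM to 60000 nM in this assay overall.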

Compound 3, concentration for 50% growth inhibition: 3200 nM
Compound 3: the middle estimate sits 9.4-fold (0.97 log units) above what was measured; measured number below the stated range.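

In this assay, among the compounds shown here, compound 3 gives the first graded number, so the group on a saturated chain carbon bound to an oxygen on an aromatic ring can change growth inhibition: cyclopentylmethyl in place of phenyl gives an at least 9.3-fold lower number from compound 2 to compound 3 (0.97 log units; beyond the scatter) in this change. Cyclopentyl in place of ethyl on a saturated chain carbon, two bonds along the chain from an oxygen on an aromatic ring, gives an at least 9.3-fold lower number from compound 1 to compound 3 (0.97 log units; beyond the scatter), so the five-membered non-aromatic ring at the chain end stands apart from both the open chain and the phenyl group, while the step between those two cannot be read. On these data alone, the full size of both new steps stays open, with the two earlier compounds held at a limit: the limit of > 30000 nM in this assay, at which 2 of the 3 values shown sit.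

The change from benzyloxy to 2-cyclopentylethoxy alters the ring and the length of the link together, so the compounds shown do not separate the two. A 2-phenylethoxy group would test the link with the aromatic ring kept, and a cyclohexylmethoxy group would test the non-aromatic ring on a shorter link.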